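The source may report more compounds than this note shows. Statements on the series, on what has been measured and on what is new or still open speak of the compounds shown alone.

Of the compounds shown here, three that share a core have so far been measured in a physicochemical assay for lipophilicity, read by HPLC, measured as chromatographic lipophilicity, at pH 7.4; a higher number here means a more lipophilic compound, a lower number a more polar compound. Compound 1 `CC[C@H]1OC(=O)[C@H](C)[C@@H](O[C@H]2C[C@@](C)(OC)[C@@H](OCCCNC(=O)C3CCC3)[C@H](C)O2)[C@H](C)[C@@H](O[C@@H]2O[C@H](C)C[C@H](N(C)C)[C@H]2O)[C@](C)(O)C[C@@H](C)CN(C)[C@H](C)[C@@H](O)[C@]1(C)O` gives 2.62. Compound 2 `CCC(=O)NCCCO[C@@H]1[C@@H](C)N(C)C[C@H](C)C[C@@](C)(O)[C@H](O[C@@H]2O[C@H](C)C[C@H](N(C)C)[C@H]2O)[C@@H](C)[C@H](O[C@H]2C[C@@](C)(OC)[C@@H](O)[C@H](C)O2)[C@@H](C)C(=O)O[C@H](CC)[C@@]1(C)O` gives 2.74, the highest of the three numbers, although its gap to compound 1 lies within the usual scatter. Compound 3 `CC[C@H]1OC(=O)[C@H](C)[C@@H](OCCCNC(=O)COC)[C@H](C)[C@@H](O[C@@H]2O[C@H](C)C[C@H](N(C)C)[C@H]2O)[C@](C)(O)C[C@@H](C)CN(C)[C@H](C)[C@@H](O)[C@]1(C)O` gives 1.4, which stands beyond the scatter below compound 2. Compound 4 `CC[C@H]1OC(=O)[C@H](C)[C@@H](O[C@H]2C[C@@](C)(OC)[C@@H](O)[C@H](C)O2)[C@H](C)[C@@H](O[C@@H]2O[C@H](C)C[C@H](N(C)C)[C@H]2O)[C@](C)(O)C[C@@H](C)CN(C)[C@H](C)[C@@H](OCCCNC(=O)COC)[C@]1(C)O` has not yet been measured. It differs from compound 2 in one place: methoxy in place of methyl on a saturated chain carbon bound to a carbonyl carbon. Among the measured compounds shown here, no measured pair shows this same change on its own, so its size cannot be read from the numbers at hand. A small decrease in this assay is expected, with an estimated step of a number 0.39 log units lower from compound 2 to compound 4 (beyond the scatter). Compound 4 is therefore estimated at 2.35, expected to fall between 1.9 and 2.8.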

Compound 4, distribution coefficient: 2.58
The estimate for compound 4 lay 0.23 log units below the measured number; the range from low to high includes it.
By their numbers in this assay, from the lowest: compound 3; then compounds 4, 1 and 2 (each within the scatter of the next).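

In this assay, among the compounds shown here, methoxy in place of methyl on a saturated chain carbon bound to a carbonyl carbon gives a number 0.16 log units lower from compound 2 to compound 4 (within the scatter), the first direct reading of this change. At this position, the entering group brings one hydrogen-bond acceptor that methyl lacks, yet the two compounds cannot be told apart. Nothing at hand explains this result. The compounds shown leave open whether an amine or a longer ethoxy chain on this carbon would stay as close to compound 2, and whether the same swap elsewhere on the shared core would give a similar result.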